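The source may hold more compounds than are shown below. What is called first, only, known or untested is meant among the compounds shown, and "the series" means these compounds.

Of the compounds shown here, three sharing one core have been tested in a functional assay on NCI-H460 cells (Homo sapiens) for inhibition, read by sulforhodamine B assay, with a stated time of 48 h; a lower number here means a stronger inhibitor of growth, a higher number a weaker inhibitor of growth. Compound 1 `CC1=CC[C@H](C(C)(C)N=C=S)CC1` is the smallest of them. In this assay compound 1 gives > 100000 nM, which is a limit of the assay rather than a number. Compound 2 `CC1=CC[C@H](C(C)(C)NC(=S)N/N=C/c2ccc(N(C)C)cc2)CC1` and compound 3 `CC1=CC[C@H](C(C)(C)NC(=S)N/N=C/c2ccc(F)cc2)CC1` carry a longer arm that ends in an aromatic ring. In this assay compound 2 gives > 100000 nM, again a limit of the assay. Compound 3, the starting point here, gives > 100000 nM in this assay, also a limit. Among the measured compounds shown here, compound 3 thus stands at the limit, and the two further values shown are limits as well, so no compound can be set apart from another. The step that the two limits leave unreadable from compound 2 to compound 3 cannot be read.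

Compound 4 `CC1=CC[C@H](C(C)(C)NC(=S)N/N=C/c2cccs2)CC1` differs from compound 3 by thiophen-2-yl in place of 4-fluorophenyl on a carbon with a double bond to nitrogen. No measured step bears directly on this change; the only measured step among these compounds sits at the limit of > 100000 nM in this assay, at which 3 of the 3 values shown sit, where every value shown rests. The expected step of a number no higher from compound 3 to compound 4 (the limit leaves the size open) is nothing beyond the scatter. Compound 4 is estimated at 100000 nM, with a range from 40000 nM to 250000 nM, most probably reported once more as a limit.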

Compound 4, concentration for total growth inhibition: 20800 nM
Compound 4: middle estimate off by 4.8-fold (0.68 log units), on the high side, and the stated range ends above it.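

The ring at the end of the arm, on a carbon with a double bond to nitrogen, turns out to be a place where a change can move the read-out. In this assay, thiophen-2-yl in place of 4-fluorophenyl gives an at least 4.8-fold lower number from compound 3 to compound 4 (0.68 log units; beyond the scatter), and this size is only a minimum, as the value for compound 3 is a limit of the assay and not a number. Compound 4 therefore gives the set its first true number, one from which later changes at this ring can be measured in either direction, while the step between the two limits of compound 2 and compound 3 still cannot be read: the limit of > 100000 nM in this assay, at which 3 of the 4 values shown sit.

This single swap replaces a six-membered aromatic ring of carbon only with a five-membered aromatic ring with 1 hetero atom and also removes the fluorine, so the compounds shown cannot separate the ring size, the sulfur and the fluorine from one another. Plain phenyl would test the fluorine alone, and furan-2-yl would test whether sulfur is needed in the five-membered ring.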